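This account rests on a few compounds, and the source may have more. Where it says the series, first, only, none or still open, it means among the compounds named here.

The measured compounds, with their values in a functional assay on HT-29 cells (Homo sapiens) for antiproliferative activity, read by MTT assay, with a stated time of 48 h; a higher number here means a weaker inhibitor, a lower number a stronger inhibitor:

compound 1 `COc1ccc(N/C=C\C(=O)c2cn(-c3ccccc3)nc2-c2ccc(F)cc2)cc1` — 3200 nM
compound 2 `COc1cc(N/C=C\C(=O)c2cn(-c3ccccc3)nc2-c2ccc(F)cc2)cc(OC)c1OC` — 7770 nM
compound 3 `COc1ccc(N/C=C\C(=O)c2cn(-c3ccccc3)nc2-c2ccc(Cl)cc2)cc1` — 8930 nM

Compound 1 and compound 3 share a core and differ only in chloro in place of fluoro on an aromatic carbon; this change produced a 2.8-fold higher number from compound 1 to compound 3 (0.45 log units; beyond the scatter). Compound 2 carries a different core; the difference between the two cores is not broken down here. In this assay compound 2 gives a number close to that of compound 3 and higher than that of compound 1. Compound 4 `COc1cc(N/C=C\C(=O)c2cn(-c3ccccc3)nc2-c2ccc(Cl)cc2)cc(OC)c1OC` has not yet been measured. It stands to compound 2 as compound 3 stands to compound 1, by chloro in place of fluoro on an aromatic carbon, the same change in the same place. Among the measured compounds shown here, the only guide is the one earlier step, so the expectation for compound 4 rests on it alone: the step from compound 2 to compound 4 is expected to be a 2.4-fold higher number from compound 2 to compound 4 (0.39 log units; beyond the scatter), about the size of the step seen from compound 1 to compound 3. On that basis compound 4 is estimated at 19000 nM in this assay, with a likely range from 8000 nM to 45000 nM.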

Compound 4, half-maximal inhibitory concentration: 12700 nM
Compound 4: middle estimate off by 1.5-fold (0.17 log units), on the high side; low and high end bracket the measured number.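

In this assay, the change from 4-fluorophenyl to 4-chlorophenyl, carried over to the second core, gives a 1.6-fold higher number from compound 2 to compound 4 (0.21 log units; within the scatter), a step that on its own cannot be told apart from no change. It also cannot be told apart from the earlier step, so the two cores give no sign that the change behaves differently from one to the other, though two pairs of compounds do not prove that it carries over unchanged, and they say nothing of any further core. Set side by side, the two steps read as follows: the same change on two cores in this assay, a 2.8-fold higher number (0.45 log units; beyond the scatter) from compound 1 to compound 3 and a 1.6-fold higher number (0.21 log units; within the scatter) from compound 2 to compound 4, 1.7-fold (0.23 log units) apart, within the scatter of two such steps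

What the compounds shown leave open is how a bromo, methyl or methoxy group would compare with fluoro and chloro at this place on either core. From the compounds shown here alone, it also remains open whether the two steps would stay this close with an amine or a carboxylic acid elsewhere on the core, or on cell lines other than this one.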